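The compounds below may be only part of what the source reports. "The series", "measured", "known", "first", "only" and "open" are said of these compounds alone.

Measured compounds in a functional assay on SMMC-7721 cells (Homo sapiens) for cytotoxicity, read by MTT assay, with a stated time of 4 days; a lower number here means a stronger inhibitor, a higher number a weaker inhibitor:
Compound 1 `C=C1C[C@]23C[C@@]1(O)CC[C@H]2c1ccc(O)c(C)c1[C@@H]3Cn1cc(-c2ccccn2)nn1` gives > 20000 nM, a limit of the assay.
Compound 2 `C=C1C(=O)[C@]23C[C@@]1(O)CC[C@H]2c1ccc(O)c(C)c1[C@@H]3Cn1cc(-c2ccc(C(F)(F)F)cc2)nn1` gives 1440 nM.
Compound 3 `C=C1C[C@]23C[C@@]1(O)CC[C@H]2c1cc(Br)c(O)c(C)c1[C@@H]3Cn1cc(-c2ccccn2)nn1` gives > 20000 nM, also a limit of the assay.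

Compound 1 stands at the limit of this assay, with no number of its own; this is the limit of > 20000 nM in this assay, at which 2 of the 3 values shown sit. Going by the values given here, the one measured step that starts from compound 1 is a step that the two limits leave unreadable from compound 1 to compound 3, and it says nothing about size. Among the compounds with values here, compound 2 differs from compound 1 in two places, a carbonyl in the shared core and a 4-(trifluoromethyl)phenyl on the five-membered aromatic ring with 3 nitrogen, and it is the only compound of the three with a measured number.

Compound 4 `C=C1C[C@]23C[C@@]1(O)CC[C@H]2c1ccc(O)c(C)c1[C@@H]3Cn1cc(-c2ccc(C)cc2)nn1` is not yet measured. It differs from compound 1 as 4-methylphenyl in place of pyridin-2-yl on an aromatic carbon. Within the data shown here, no measured step isolates this change. The value of compound 2 gives the only hint that a carbon-only ring at this place is compatible with a measurable number, but compound 2 also carries the carbonyl, so the hint is weak. Compound 4 is expected to improve on the limit of compound 1 by an at least 1.6-fold lower number from compound 1 to compound 4 (0.22 log units; that floor lies within the scatter), if at all, with a real chance that this assay again reports only a limit. The estimate for compound 4 is 12000 nM, between 3000 nM and 40000 nM.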

Compound 4, half-maximal inhibitory concentration: > 20000 nM
Compound 4: no number, only a limit; the forecaster's own chance of this, stated with the estimate: 45%; middle value at least 1.6-fold (0.22 log units) away from the limit.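

In this assay compound 4 gives > 20000 nM, a limit of the assay and not a number. Compound 1 also sits at a limit, so no step between compound 1 and compound 4 can be read: the limit of > 20000 nM in this assay, at which 3 of the 4 values shown sit.

The compounds shown leave open whether the carbonyl, the 4-(trifluoromethyl)phenyl or both account for the measured number of compound 2.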